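A Single-Chlorine Phenyl Replaces the Dichlorophenyl

The compounds below may be only part of what the source reports. "The series", "measured", "known", "first", "only" and "open" are said of these compounds alone.

Of the compounds shown here, two have been tested in an assay on isolated protein for inhibition of protein kinase C zeta type (Homo sapiens), read by 33P incorporation, tested at 50 uM; a lower number here means a weaker effect, a higher number a stronger effect of the compound at the concentration tested. Compound 1 `O=C(O)CC(Cc1nc2cc(I)ccc2[nH]1)c1cccc(Cl)c1` gives 14%. Compound 2 `O=C(O)CC(Cc1nc2cc(Cl)ccc2[nH]1)c1ccc(Cl)cc1Cl` gives 30%, the higher of the two numbers, and its gap to compound 1 lies beyond the scatter. Compound 3 `O=C(O)CC(Cc1nc2cc(Cl)ccc2[nH]1)c1cccc(Cl)c1` shares the core of compound 2 and differs from it in one place: 3-chlorophenyl in place of 2,4-dichlorophenyl on a saturated chain carbon bound to two saturated chain carbons. Among the compounds with values here, no measured pair shows this change directly. Compound 3 is expected to fall by a moderate step from compound 2, a number 13 percentage points lower from compound 2 to compound 3 (beyond the scatter), because compound 1 gives 14% with the same 3-chlorophenyl group. The estimate for compound 3 in this assay is 17%, between 5% and 32%.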

Compound 3, a percentage reported as inhibition, at one concentration (the size of the read-out at that concentration, not a potency): 0%
Compound 3: the middle estimate sits 17 percentage points above what was measured, and the stated range ends above it.
By their numbers in this assay, from the lowest: compound 3; then compound 1; then compound 2.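

In this assay, the step to 3-chlorophenyl on this saturated chain carbon, with the rest of the molecule unchanged, gives a number 30 percentage points lower from compound 2 to compound 3 (beyond the scatter), so the reading depends on the phenyl group at this place. With 3-chlorophenyl kept, chloro in place of iodo on an aromatic carbon gives a number 14 percentage points lower from compound 1 to compound 3 (beyond the scatter), so the halogen on the core also changes the reading. No measurement here accounts for either step. Still open, from the compounds shown here alone, is how 4-chlorophenyl or a phenyl without chlorine would read at this chain carbon. Also open, going by these compounds, is how bromo would read in place of chloro or iodo on that aromatic carbon.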